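Dimethoxyphenyl for chlorofluorophenyl in a semicarbazone series

This account rests on a few compounds, and the source may have more. Where it says the series, first, only, none or still open, it means among the compounds named here.

Compound 2 `CN(C)CCn1cnnc1-c1cc(Oc2ccc(NC(=O)N/N=C/c3ccc(F)cc3Cl)cc2F)ccn1`: 2090 nM
Compound 1 `COc1ccc(OC)c(/C=N/NC(=O)Nc2ccc(Oc3ccnc(-c4nncn4CCN(C)C)c3)c(F)c2)c1`: "not determined" (no result reported)
Compound 3 `CN(C)CCn1cnnc1-c1cc(Oc2ccc(NC(=O)N/N=C/c3ccc(O)c(F)c3)cc2F)ccn1`: "not determined" (no result reported)

Three semicarbazones sharing one core were taken into an ADME assay on WI-38 cells (Homo sapiens) for cytotoxicity, read by MTT assay, with a stated time of 72 h; a higher number here means a weaker inhibitor, a lower number a stronger inhibitor. In this assay compound 1 gives "not determined" (no result reported) and compound 3 gives "not determined" (no result reported), so compound 2 stands alone with a value: in this assay compound 2 gives 2090 nM, the only figure against which anything in this set can be placed. Among the measured compounds shown here, with no pair of measured compounds differing in a single place, no step within the measured set can be stated.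

Compound 4 `COc1ccc(/C=N/NC(=O)Nc2ccc(Oc3ccnc(-c4nncn4CCN(C)C)c3)c(F)c2)c(OC)c1` is the next compound to be measured. It differs from compound 2 in one place: 2,4-dimethoxyphenyl in place of 2-chloro-4-fluorophenyl on a carbon with a double bond to nitrogen

For the measured compounds named here, because the one anchor is compound 2 at 2090 nM, and no measured step in this assay shows how a change of this kind has moved the read-out, the expectation for compound 4 is cautious. The step of a 1.4-fold higher number from compound 2 to compound 4 (0.16 log units; within the scatter) is expected to be small, towards a weaker inhibitor if anything, and likely within the usual scatter of the measurement. Compound 4 is therefore estimated at 3000 nM, with a range from 1000 nM to 9000 nM.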

Compound 4, half-maximal inhibitory concentration: 6630 nM
Compound 4: middle estimate off by 2.2-fold (0.34 log units), on the low side; the range from low to high includes it.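

In this assay the set now holds its first readable step: with 2,4-dimethoxyphenyl in place of 2-chloro-4-fluorophenyl on a carbon with a double bond to nitrogen, the result is a 3.2-fold higher number from compound 2 to compound 4 (0.50 log units; beyond the scatter) and lies beyond the usual scatter. Among the compounds shown here, this shows that the read-out responds to a change at this place while the rest of the structure stays the same, something the lone value of the earlier compounds could not show, and the direction here is towards a weaker inhibitor. The change swaps two halogens on the ring for two methoxy groups, but nothing measured on these compounds bears on why the number moved.

For the compounds shown here, compound 1 and compound 3 carry no number, so no steps to them can be read, and the single step cannot separate the loss of the chlorine or the fluorine from the gain of either methoxy group. As far as these compounds go, it also remains open whether a phenyl ring bearing a single methoxy group, an amine or a carboxylic acid would shift the read-out in the same direction, and by how much.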